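A few compounds are considered here, and "the series" means these few. Any claim that something is new, unique, unknown or untested is made for them only; others in the source may bear on it.

Measured so far in a functional assay on HeLa cells (Homo sapiens) for cytotoxicity, read by MTT assay, with a stated time of 72 h; a lower number here means a stronger inhibitor, a higher number a weaker inhibitor:

- compound 1 `O=C(NCCO)c1cc2ccc(OCc3ccccc3)cc2oc1=O`: 14200 nM
- compound 2 `O=C(NCCO)c1cc2ccc(OCc3cccc(Br)c3)cc2oc1=O`: 17600 nM
- compound 3 `NNC(=O)c1cc2ccc(OCc3ccccc3)cc2oc1=O`: the result for compound 3 is a limit of the assay, > 100000 nM

Compound 2 differs from compound 1 by bromo in place of hydrogen on an aromatic carbon. The step this makes in this assay is a 1.2-fold higher number from compound 1 to compound 2 (0.09 log units; within the scatter), so the two values are indistinguishable within the usual spread of such measurements.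

Compound 3 carries a different core. The difference between the core of compound 1 and the core of compound 3 is amino in place of 2-hydroxyethyl on an amide-type nitrogen, and the step in this assay is an at least 7.0-fold higher number from compound 1 to compound 3 (0.84 log units; beyond the scatter). The size of that step is bounded by the fact that one of the three values sits at the limit of > 100000 nM in this assay, at which 1 of the 3 values shown sits, so only a lower bound on the loss can be given.

Compound 4 `NNC(=O)c1cc2ccc(OCc3cccc(Br)c3)cc2oc1=O` has not yet been measured in this assay. It differs from compound 3 by bromo in place of hydrogen on an aromatic carbon, which is the same change as that from compound 1 to compound 2, made on the same place of the ring and against the core of compound 3 rather than the core of compound 1. Since the same change on the other core gave a 1.2-fold higher number from compound 1 to compound 2 (0.09 log units; within the scatter), the step from compound 3 to compound 4 is expected to be about as flat, a step that the limit leaves unreadable from compound 3 to compound 4. Compound 4 is therefore estimated at 130000 nM, between 60000 nM and 400000 nM, and it is expected that this assay will again return only a limit rather than a number.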

Compound 4, half-maximal inhibitory concentration: > 100000 nM
Compound 4 ended at the assay's limit; the forecaster's own chance of this, stated with the estimate: 80%; the middle value is on the limit's open side.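

In this assay, amino in place of 2-hydroxyethyl on the amide-type nitrogen weakens the compound on both cores, and on the core carrying the 3-bromobenzyl group the step is an at least 5.6-fold higher number from compound 2 to compound 4 (0.75 log units; beyond the scatter). Set side by side, the two steps read: the same change on two cores in this assay, an at least 7.0-fold higher number (0.84 log units; beyond the scatter) from compound 1 to compound 3 and an at least 5.6-fold higher number (0.75 log units; beyond the scatter) from compound 2 to compound 4; the limit leaves it open whether they differ

The direction of the change therefore carries over from one core to the other in this pair of comparisons, but its size does not become known, and nothing shows that the two losses are equal or that they differ. Compound 3 and compound 4 both stand as limits of the assay and not as numbers, so the steps between them cannot be read, and the bromo change leaves no visible result among the amino compounds.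

The compounds shown leave open which part of the 2-hydroxyethyl chain matters, and a 2-methoxyethyl group, a plain ethyl group or a longer chain on the amide-type nitrogen would separate the hydroxyl from the chain itself. Within the data shown here, also open is what a methoxy group or a nitrile in place of bromo would do on the benzyl ring; the one readable bromo step is a 1.2-fold higher number from compound 1 to compound 2 (0.09 log units; within the scatter).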